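This account rests on a few compounds, and the source may have more. Where it says the series, first, only, none or still open, it means among the compounds named here.

The series shares one core, carried by compound 1 `CCN(CC)S(=O)(=O)c1ccc(S(=O)(=O)N2CCC[C@@H](C(=O)NC3CN(C(=O)C4CC4)C3)C2)cc1`, compound 2 `CCN(CC)S(=O)(=O)c1ccc(S(=O)(=O)N2CCC[C@@H](C(=O)N(C)C(C)C)C2)cc1` and compound 3 `CCOC(=O)[C@@H]1CCCN(S(=O)(=O)c2ccc(S(=O)(=O)N(CC)C(C)C)cc2)C1`. In a functional assay on BXPC-3 cells (Homo sapiens) for inhibition, read by MTT assay, with a stated time of 7 days (on this read-out higher numbers stand for weaker inhibition and lower numbers for stronger inhibition), compound 1 gives 18500 nM, compound 2 gives 7700 nM and compound 3 gives 1600 nM. For the measured compounds named here, the only step between compounds that differ in one place is a 2.4-fold lower number from compound 1 to compound 2 (0.38 log units; beyond the scatter). Compound 3 holds the lowest of the three numbers; compound 2 is its nearest neighbour and compound 1 lies furthest away, and both of those gaps are beyond the scatter.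

Compound 4 `CCOC(=O)[C@@H]1CCCN(S(=O)(=O)c2ccc(S(=N)(=O)N(CC)CC)cc2)C1` has not been measured. It differs from compound 3 in one place: a group of 8 heavy atoms (4 carbon, 2 nitrogen, 1 oxygen, 1 sulfur; no ring) in place of a group of 9 heavy atoms (5 carbon, 1 nitrogen, 2 oxygen, 1 sulfur; no ring), on an aromatic carbon. Going by the values given here, no measured step touches this part of the core: the single known step in this assay sits at the carbonyl carbon and says nothing about a change on the aromatic carbon para to the large group. Without a precedent, no step beyond the scatter is assumed in either direction, and the open point is whether the hydrogen-bond donor that enters moves the number at all. Compound 4 is therefore expected at 2500 nM, within a range from 900 nM to 7000 nM. The step this estimate implies is a 1.6-fold higher number from compound 3 to compound 4 (0.19 log units; within the scatter).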

Compound 4, half-maximal inhibitory concentration: 3600 nM
The estimate for compound 4 lay 1.4-fold (0.16 log units) below the measured number, and the stated range covers the measured number.
By their numbers in this assay, from the lowest: compound 3; then compound 4; then compound 2; then compound 1.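

In this assay the change on the aromatic carbon para to a large group gives a 2.3-fold higher number from compound 3 to compound 4 (0.35 log units; beyond the scatter), so this position responds to the replacement of ethyl(isopropyl)sulfamoyl, though the step is modest. The replacement is not a single-feature change: the entering group has 8 heavy atoms against 9, a different atom make-up and 1 hydrogen-bond donor against 0, while both groups have 2 hydrogen-bond acceptors and no net charge, so the step cannot be assigned to any one of these differences. No supporting data bear on the origin of this step.

Still open, on these data alone, is whether the hydrogen-bond donor or the remaining change in the group accounts for the step; a methyl on the nitrogen that carries the hydrogen, or propyl chains in place of the ethyl chains, would help separate the two. Also open, as far as these compounds go, is whether the same step holds when the ethyl ester of compound 3 and compound 4 gives way to an amide such as the isopropyl(methyl)amino carbonyl of compound 2.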